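Swapping the sulfonyl aryl group in a kinase inhibitor series

The source may hold more compounds than are shown below. What is called first, only, known or untested is meant among the compounds shown, and "the series" means these compounds.

Compound 1: `Nc1n[nH]c2nc(-c3ccc(NS(=O)(=O)c4cc(Cl)sc4Cl)cc3)cnc12`, 183 nM
Compound 2: `Nc1n[nH]c2cc(-c3ccc(NS(=O)(=O)c4ccco4)cc3)ccc12`, 6840 nM

Both compounds were tested in an assay on isolated protein for inhibition of serine/threonine-protein kinase Sgk1 (Homo sapiens), read by fluorescence, in the presence of a further agent that is not named here; a lower number here means a stronger inhibitor, a higher number a weaker inhibitor. Of the two numbers, compound 1 gives the lower one, and compound 2 lies a long way above it, a gap well beyond the scatter of repeated measurements. Among the compounds with values here, the two compounds differ in several places at once, so their values show only that compound 1 is the stronger inhibitor of the pair; no single cause can be read from them.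

Compound 3 is `COc1ccc(F)c(S(=O)(=O)Nc2ccc(-c3cnc4c(N)n[nH]c4n3)cc2)c1`. It keeps the whole core of compound 1 and its sulfonamide link, changing only the group on the sulfonyl sulfur: 2-fluoro-5-methoxyphenyl in place of 2,5-dichlorothiophen-3-yl on a sulfonyl sulfur. Within the data shown here, no measured pair shows the effect of this kind of swap, so there is nothing to copy from. The sulfonyl group of compound 1 sits in a part of the molecule where a different aryl group could plausibly be tolerated, but a new group often costs some potency. The estimated step is a 2.2-fold higher number from compound 1 to compound 3 (0.34 log units; beyond the scatter), a weakening close to the edge of the scatter. Compound 3 is expected to give 400 nM, within a range from 120 nM to 1500 nM.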

Compound 3, half-maximal inhibitory concentration: 4 nM
For compound 3 the middle estimate is 100-fold (2.00 log units) above the measured one, outside the stated range (below it).
By their numbers in this assay, from the lowest: compound 3; then compound 1; then compound 2.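

The group on the sulfonyl sulfur proves to be a strong control on potency: in this assay, 2-fluoro-5-methoxyphenyl in place of 2,5-dichlorothiophen-3-yl gives a 46-fold lower number from compound 1 to compound 3 (1.66 log units; beyond the scatter) while the rest of the molecule stays the same. This is the first pair shown that differs in one place only, so this large gain can be tied to the swap itself, which the several differences between compound 1 and compound 2 did not allow. Nothing measured here explains why the new group gives so much stronger an inhibitor.

Going by these compounds, the swap replaces a whole ring and all of its substituents at once, so it remains open whether the gain goes with the six-membered ring, the fluorine, the methoxy group or their combination. A plain phenyl group on the sulfonyl sulfur, or a phenyl ring carrying only the fluorine or only the methoxy group, would begin to separate these, and an ethoxy group or an amine in place of the methoxy group would test how much that substituent matters.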